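Aryl swap on a weakly cytotoxic amide series

The source may report more compounds than this note shows. Statements on the series, on what has been measured and on what is new or still open speak of the compounds shown alone.

Measured so far:
compound 1 `Cc1cc(=O)n(-c2ccccc2OC(F)(F)F)nc1C(=O)Nc1ccc(Oc2ncnc3[nH]ccc23)cc1` — 22800 nM
compound 2 `Cc1cc(=O)n(-c2ccccc2OC(F)(F)F)nc1C(=O)Nc1ccc(Oc2ncnc3c2ccn3C)cc1` — > 60000 nM

In a functional assay on HepG2 cells (Homo sapiens) for cytotoxicity, read by MTT assay, with a stated time of 72 h (a lower number here means a stronger inhibitor, a higher number a weaker inhibitor), compound 1 gives 22800 nM. For compound 2 the assay reports only a limit, > 60000 nM. The step of an at least 2.6-fold higher number from compound 1 to compound 2 (0.42 log units; beyond the scatter) reaches (the limit of > 60000 nM in this assay, at which 1 of the 2 values shown sits), so compound 2 stands at the weak end of what the assay shows. Compound 3 `Cc1cc(=O)n(-c2cccc(F)c2)nc1C(=O)Nc1ccc(Oc2ncnc3c2ccn3C)cc1` differs from compound 2 by 3-fluorophenyl in place of 2-(trifluoromethoxy)phenyl on an aromatic nitrogen. Among the compounds with values here, no measured step touches this position, and the one measured step concerns a different part of the shared core. Compound 3 is therefore expected to remain near the limit, at about 60000 nM (range 30000 nM to 120000 nM), with a number no higher from compound 2 to compound 3 (the limit leaves the size open) expected to lie within the scatter.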

Compound 3, half-maximal inhibitory concentration: > 60000 nM
Compound 3: a limit, no number (the forecaster's own chance of this, stated with the estimate: 70%); the middle value sits exactly at the limit.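

Compound 3 gives only a limit, > 60000 nM, and compound 2 also stands at a limit, so no step between compound 2 and compound 3 can be read: the limit of > 60000 nM in this assay, at which 2 of the 3 values shown sit.

On these data alone, whether 3-fluorophenyl in place of 2-(trifluoromethoxy)phenyl changes the number at all remains open.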